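The source may hold more compounds than are shown below. What is called first, only, known or untested is meant among the compounds shown, and "the series" means these compounds.

Measured compounds:
compound 1, `C=C1C(=O)O[C@@H]2/C=C(\C)CCC[C@H](C)CC[C@H]12`: 35.1 ug/mL
compound 2, `C/C1=C\[C@H]2OC(=O)[C@@H](C)[C@@H]2CC/C(C)=C/CC1`: 57.9 ug/mL

In a functional assay on MCF7 cells (Homo sapiens) for cytotoxicity, read by MTT assay, with a stated time of 48 h (on this read-out higher numbers stand for weaker inhibition and lower numbers for stronger inhibition), compound 2 gives the highest of the two numbers; compound 1 comes nearest with 35.1 ug/mL, a gap within the scatter, so no order between the two is claimed. The next compound, compound 3, `COC[C@@H]1C(=O)O[C@@H]2/C=C(\C)CC/C=C(\C)CC[C@@H]12`, is unmeasured. Its change from compound 2 reads (methoxy in place of hydrogen on a saturated chain carbon bound to a saturated ring carbon). For the measured compounds named here, no step between measured compounds is available to calibrate this change, and nothing in the two numbers points one way. For compound 3 a step of a 1.3-fold lower number from compound 2 to compound 3 (0.11 log units; within the scatter) is expected, nothing beyond the scatter. Compound 3 is estimated at 45 ug/mL, range 20 ug/mL to 100 ug/mL.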

Compound 3, half-maximal inhibitory concentration: 75.1 ug/mL
Compound 3: the middle estimate sits 1.7-fold (0.22 log units) below what was measured; low and high end bracket the measured number.
By their numbers in this assay, from the lowest: compounds 1, 2 and 3 (each within the scatter of the next, the first and the last beyond it).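

In this assay, methoxy in place of hydrogen on a saturated chain carbon bound to a saturated ring carbon gives a 1.3-fold higher number from compound 2 to compound 3 (0.11 log units; within the scatter). For the compounds shown here, this is the first step read at this position, and the change from methyl to methoxymethyl stays within the scatter, so it separates neither compound. No measurement bearing on the origin of this step is available.

From the compounds shown here alone, whether an amine or a carboxylic acid in place of the methoxy group gives a step beyond the scatter stays open. A single step also leaves open how other groups at this carbon compare.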